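Methyl to Trifluoromethyl: Expected Shift in Growth Inhibition

The source may report more compounds than this note shows. Statements on the series, on what has been measured and on what is new or still open speak of the compounds shown alone.

Measured in a functional assay on WM 266-4 cells (Homo sapiens) for antiproliferative activity, read by MTT assay, with a stated time of 48 h; a higher number here means a weaker inhibitor of growth, a lower number a stronger inhibitor of growth:
compound 1 `Fc1ccc(C2=NN(C(=S)Nc3ccccc3)C(c3ccc4c(c3)OCCO4)C2)cc1` gives 22500 nM
compound 2 `S=C(Nc1ccccc1)N1N=C(c2ccc(Br)cc2)CC1c1ccc2c(c1)OCCO2` gives 870 nM
compound 3 `Cc1ccc(C2=NN(C(=S)Nc3ccccc3)C(c3ccc4c(c3)OCCO4)C2)cc1` gives 10300 nM

Compound 3 stands second highest of these three numbers: its value lies above that of compound 2, a step of a 12-fold higher number from compound 2 to compound 3 (1.07 log units; beyond the scatter), and below that of compound 1, a step of a 2.2-fold lower number from compound 1 to compound 3 (0.34 log units; beyond the scatter). Compound 4 `FC(F)(F)c1ccc(C2=NN(C(=S)Nc3ccccc3)C(c3ccc4c(c3)OCCO4)C2)cc1` differs from compound 3 by trifluoromethyl in place of methyl on an aromatic carbon. The measured steps that bear on this position are a 26-fold lower number from compound 1 to compound 2 (1.41 log units; beyond the scatter), a 2.2-fold lower number from compound 1 to compound 3 (0.34 log units; beyond the scatter) and a 12-fold higher number from compound 2 to compound 3 (1.07 log units; beyond the scatter), so exchanging the group here has moved the number modestly or a great deal. Among the compounds with values here, no measured step brings in trifluoromethyl, so the direction is uncertain. Compound 4 is expected to give 5000 nM, with a range from 1000 nM to 25000 nM, an estimated step of a 2.1-fold lower number from compound 3 to compound 4 (0.31 log units; beyond the scatter).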

Compound 4, concentration for 50% growth inhibition: 52400 nM
Compound 4: middle estimate off by 10-fold (1.02 log units), on the low side; measured number outside the range, above it.
By their numbers in this assay, from the lowest: compound 2; then compound 3; then compound 1; then compound 4.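

Trifluoromethyl gives the weakest inhibitor of the four, with a 5.1-fold higher number from compound 3 to compound 4 (0.71 log units; beyond the scatter) and a 2.3-fold higher number from compound 1 to compound 4 (0.37 log units; beyond the scatter) placing it above both methyl and fluoro. Bromo remains the strongest, and a 60-fold higher number from compound 2 to compound 4 (1.78 log units; beyond the scatter) is the widest gap yet seen at this position. Nothing available explains this order of the groups.

From the compounds shown here alone, whether chloro, methoxy or an amine at this position would sit nearer bromo or nearer trifluoromethyl stays open. So does whether the same order would hold if another part of the shared core were changed.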